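A few compounds are considered here, and "the series" means these few. Any claim that something is new, unique, unknown or untested is made for them only; others in the source may bear on it.

Compound 1 `COC(=O)c1cccc(-c2cnc3[nH]cc(-c4cccnc4)c3c2)c1`: in an assay on isolated protein for inhibition of serine/threonine-protein kinase Nek1 (Homo sapiens), read by radiometric assay and 33P incorporation, in the presence of a further agent that is not named here (a lower number here means a stronger inhibitor, a higher number a weaker inhibitor), compound 1 gives 11.5 nM.
Compound 2 `c1ccc(Nc2nccc(Nc3cc(C4CC4)[nH]n3)n2)cc1`: in this assay compound 2 gives 850 nM.
Compound 3 `COC(=O)c1cccc(-c2cnc3[nH]cc(-c4ccncc4)c3c2)c1`: in this assay compound 3 gives 140 nM.

Among these three numbers compound 1 stands lowest. Among the compounds with values here, its nearest neighbour is compound 3, and the step of a 12-fold higher number from compound 1 to compound 3 (1.09 log units; beyond the scatter) is the only single-point change among the measured compounds. Compound 2 shares no core with compound 1, so its value is simply the highest of the three and says nothing about one change in isolation.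

The unmeasured compound 4 `COC(=O)c1cccc(-c2cnc3[nH]cc(-c4ccccc4)c3c2)c1` keeps the core of compound 1 and differs from it in one place: phenyl in place of pyridin-3-yl on an aromatic carbon. Within the data shown here, the step that bears on this is the one from compound 1 to compound 3, where moving the ring nitrogen within the same six-membered ring already gave a large rise in the number. Compound 4 removes that nitrogen altogether, and the data hold no case where the ring nitrogen is absent. The expectation is therefore a step in this assay in the same direction, of about the same size, rather than none within the scatter.

On that basis compound 4 is estimated at 110 nM, with a range from 25 nM to 500 nM. This estimate corresponds to an expected step of a 9.6-fold higher number from compound 1 to compound 4 (0.98 log units; beyond the scatter).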

Compound 4, half-maximal inhibitory concentration in the serine/threonine-protein kinase Nek1 assay: 123 nM
Compound 4: the middle estimate sits 1.1-fold (0.05 log units) below what was measured; the measured number falls inside the stated range.
By their numbers in the serine/threonine-protein kinase Nek1 assay, from the lowest: compound 1; then compounds 4 and 3 (each within the scatter of the next); then compound 2.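

In the serine/threonine-protein kinase Nek1 assay the new result sets pyridin-3-yl apart at this position: replacing it with phenyl gives a large step (an 11-fold higher number from compound 1 to compound 4 (1.03 log units; beyond the scatter)), whereas replacing pyridin-4-yl with phenyl gives a step within the scatter (a 1.1-fold lower number from compound 3 to compound 4 (0.06 log units; within the scatter)), so compounds 3 and 4 cannot be told apart here and a ring nitrogen as such brings no advantage unless it is placed as in compound 1. The same change does not separate the compounds in a physicochemical assay for solubility, read by HPLC, using the shake flask method (on this read-out higher numbers stand for higher solubility and lower numbers for lower solubility), where compound 1 gives (1900 nM), compound 4 gives (2500 nM) and the step lies within the scatter (a 1.3-fold higher number from compound 1 to compound 4 (0.12 log units; within the scatter)). Nothing available explains why only the pyridin-3-yl compound stands apart in the kinase data.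

Still open, from the compounds shown here alone, is what a pyridin-2-yl ring on this aromatic carbon would do, and whether a small amine on the pyridin-3-yl ring would keep the low number of compound 1. Also open, going by these compounds, is how a carboxylic acid in place of the methyl ester would behave in either assay, on which compound 2, with no core in common with the others, offers no guidance.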